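A few compounds are considered here, and "the series" means these few. Any claim that something is new, unique, unknown or untested is made for them only; others in the source may bear on it.

Measured in an ADME assay on HepG2 2.2.15 cells (Homo sapiens) for cytotoxicity, read by CCK-8 assay, with a stated time of 8 days; a higher number here means that more compound is tolerated, a lower number that less compound is tolerated:
- compound 1 `COc1ccc(-c2cc(NC(=O)c3ccc(C)cc3O)c[nH]c2=O)cc1`: 46100 nM
- compound 2 `CCOc1ccc(-c2cc(NC(=O)c3ccc(OC)cc3O)c[nH]c2=O)cc1`: 69600 nM
- compound 3 `CCOc1ccc(-c2cc(NC(=O)c3cccc(OC)c3O)c[nH]c2=O)cc1`: 34500 nM

In this assay, compound 3 lies within the scatter of both compound 1 and compound 2. Compound 4 `CCOc1ccc(-c2cc(NC(=O)c3ccc(C)cc3O)c[nH]c2=O)cc1` has 2-hydroxy-4-methylphenyl in place of 2-hydroxy-3-methoxyphenyl on a carbonyl carbon. Among the compounds with values here, the one measured step that bears on this change is a 2.0-fold lower number from compound 2 to compound 3 (0.30 log units; within the scatter), and it concerns only the methoxy-bearing groups. Compound 1 carries the entering group and gives 46100 nM, so no change beyond the scatter is expected. The expected step is a 1.3-fold higher number from compound 3 to compound 4 (0.12 log units; within the scatter). For compound 4 the estimated value is 46000 nM, with an expected range of 25000 nM to 85000 nM.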

Compound 4, half-maximal cytotoxic concentration: > 100000 nM
Compound 4 was reported as a limit; the forecaster's own chance of this, stated with the estimate: 10%; at least 2.1-fold (0.33 log units) between middle value and limit.
By their numbers in this assay, from the lowest: compounds 3, 1 and 2 (each within the scatter of the next). At a limit, above all of these: compound 4.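

In this assay compound 4 gives > 100000 nM as a limit of the assay and not as a number. Placing 2-hydroxy-4-methylphenyl for 2-hydroxy-3-methoxyphenyl on a carbonyl carbon yields an at least 2.8-fold higher number from compound 3 to compound 4 (0.46 log units; beyond the scatter) and methyl in place of hydrogen on a saturated chain carbon bound to an oxygen yields an at least 2.1-fold higher number from compound 1 to compound 4 (0.33 log units; beyond the scatter) so both steps, unlike the earlier one, pass the scatter. Methyl in place of methoxy on an aromatic carbon yields an at least 1.4-fold higher number from compound 2 to compound 4 (0.15 log units; that floor lies within the scatter) and so remains unresolved.

As far as these compounds go, how far compound 4 lies past its limit stays open, as does whether chlorine or an amine in place of that methyl would be tolerated as well.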